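A Chlorine Added to the Phenyl Ring of Compound 3

This account rests on a few compounds, and the source may have more. Where it says the series, first, only, none or still open, it means among the compounds named here.

Three compounds have been measured in a functional assay on HT-29 cells (Homo sapiens) for cytotoxicity, read by MTT assay, with a stated time of 72 h; a higher number here means a weaker inhibitor, a lower number a stronger inhibitor:
Compound 1 `COc1ccc(/C=N/c2c(C)n(C)n(-c3ccccc3)c2=O)cc1` gives 589000000 nM.
Compound 2 `Cc1c(/N=C/c2ccccc2Cl)c(=O)n(-c2ccccc2)n1C` gives 309000000 nM.
Compound 3 `Cc1c(/N=C/c2ccccc2)c(=O)n(-c2ccccc2)n1C` gives 851000000 nM.

Compound 3 carries the highest number of the three; compound 1 lies within the scatter of it, while the step of a 2.8-fold higher number from compound 2 to compound 3 (0.44 log units; beyond the scatter) is the only one beyond the scatter. Compound 4 `Cc1c(/N=C/c2cccc(Cl)c2)c(=O)n(-c2ccccc2)n1C` differs from compound 3 by chloro in place of hydrogen on an aromatic carbon. The most relevant guide is a 2.8-fold higher number from compound 2 to compound 3 (0.44 log units; beyond the scatter), where a chloro left a 2-chlorophenyl; here a chloro enters to give a 3-chlorophenyl instead. The step of a 1.4-fold higher number from compound 1 to compound 3 (0.16 log units; within the scatter) shows a methoxy leaving made little difference. A modest lowering is therefore expected, a 1.7-fold lower number from compound 3 to compound 4 (0.23 log units; within the scatter). Compound 4 is estimated at 500000000 nM, between 250000000 nM and 1000000000 nM.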

Compound 4, half-maximal inhibitory concentration: 269000000 nM
For compound 4 the middle estimate is 1.9-fold (0.27 log units) above the measured one, and the stated range covers the measured number.
By their numbers in this assay, from the lowest: compounds 4, 2, 1 and 3 (each within the scatter of the next, the first and the last beyond it).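

In this assay, chloro in place of hydrogen, meta to a large group, gives a 3.2-fold lower number from compound 3 to compound 4 (0.50 log units; beyond the scatter), so a chloro lowers the number at this second ring position too, not only in 2-chlorophenyl. The two chlorophenyl compounds barely separate, with a 1.1-fold lower number from compound 2 to compound 4 (0.06 log units; within the scatter), whereas 3-chlorophenyl against 4-methoxyphenyl gives a 2.2-fold lower number from compound 1 to compound 4 (0.34 log units; beyond the scatter). Nothing available explains why the chloro has this effect.

Still open, going by these compounds, is how 4-chlorophenyl would compare, and whether a bromo, an amine or a carboxylic acid at this position would move the number further.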